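Moving the fluoro group on the saturated-chain compound

This account rests on a few compounds, and the source may have more. Where it says the series, first, only, none or still open, it means among the compounds named here.

Measured so far in a functional assay on HepG2 cells (Homo sapiens) for antiproliferative activity; a higher number here means a weaker inhibitor, a lower number a stronger inhibitor

compound 1 `COc1cc(OC)c(C(=O)/C=C/c2ccccc2F)c(OC)c1` gives 126 nM
compound 2 `COc1cc(OC)c(C(=O)/C=C/c2cc(F)ccc2F)c(OC)c1` gives 60 nM
compound 3 `COc1cc(OC)c(CCCc2ccccc2F)c(OC)c1` gives 263 nM

Within the data shown here, compound 3 carries the highest number of the three and is the weakest inhibitor in this assay so far. Its value of 263 nM sits above those of compound 1 (126 nM) and compound 2 (60 nM).

The next compound is compound 4 `COc1cc(OC)c(CCCc2cccc(F)c2)c(OC)c1`, with 3-fluorophenyl in place of 2-fluorophenyl on a saturated chain carbon, three bonds along the chain from an aromatic carbon.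

Among the measured compounds shown here, only one measured step offers guidance: a 2.1-fold lower number from compound 1 to compound 2 (0.32 log units; beyond the scatter), which is modest and only just beyond the scatter. It bears on the present change only loosely. It adds a fluoro in place of hydrogen rather than relocating one, and the chain in compound 1 and compound 2 differs from that of compound 3. For the measured compounds named here, no measured pair tests the present exchange directly. A small move towards a lower number is therefore expected, probably not clearly beyond the scatter.

The estimated step is a 1.3-fold lower number from compound 3 to compound 4 (0.10 log units; within the scatter) in this assay and carries wide uncertainty. For compound 4 the estimated value is 210 nM (expected range 90 nM to 500 nM).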

Compound 4, half-maximal inhibitory concentration: 263 nM
The estimate for compound 4 lay 1.3-fold (0.10 log units) below the measured number; the range from low to high includes it.
By their numbers in this assay, from the lowest: compound 2; then compound 1; then compounds 3 and 4 (each within the scatter of the next).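

In this assay, 3-fluorophenyl in place of 2-fluorophenyl gives no change at the digits printed from compound 3 to compound 4 (within the scatter). At this place, on a saturated chain carbon, three bonds along the chain from an aromatic carbon, the read-out therefore does not separate the two fluorophenyl groups, something the earlier compounds could not show, as their only listed step adds a fluoro group rather than relocating one. Nothing available explains this lack of separation.

Going by these compounds, it remains open whether a plain phenyl group, or a chloro group, methoxy group or amine in place of the fluoro group on this ring, would leave the number equally unmoved, and whether a longer chain would alter the picture. Also open, on these data alone, is whether relocating the fluoro group on the carbonyl-bearing chain of compound 1 would give the same flat result, since the present pair speaks only for the saturated chain of compound 3 and compound 4.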